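Series notes: para substituent on the anilino ring

The compounds below may be only part of what the source reports. "The series", "measured", "known", "first", "only" and "open" are said of these compounds alone.

Measured so far:
compound 1, `COc1cc(/C=C/c2nc(N(C)C)c3sccc3n2)cc(OC)c1OC` — > 1000000 nM (a limit)
compound 2, `COc1cc(/C=C/c2nc(NC3CC3)c3sccc3n2)cc(OC)c1OC` — > 1000000 nM (a limit)
compound 3, `COc1cc(/C=C/c2nc(Nc3ccc(C(C)C)cc3)c3sccc3n2)cc(OC)c1OC` — 370000 nM

In a functional assay on L02 cells (Homo sapiens) for inhibition, read by Griess assay, with stated times of 1 h and 24 h (a lower number here means a stronger inhibitor, a higher number a weaker inhibitor), compound 1 reaches only a limit, > 1000000 nM. Compound 2 likewise reaches only a limit, > 1000000 nM. Compound 3 alone gives a number, 370000 nM, and so stands as the only readable point in this assay; the other two values sit at the limit of > 1000000 nM in this assay, at which 2 of the 3 values shown sit. The step that the two limits leave unreadable from compound 1 to compound 2 cannot be read. The steps of an at least 2.7-fold lower number from compound 1 to compound 3 (0.43 log units; beyond the scatter) and an at least 2.7-fold lower number from compound 2 to compound 3 (0.43 log units; beyond the scatter) both run downward and are at least modest.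

Compound 4, `COc1cc(/C=C/c2nc(Nc3ccc(C(F)(F)F)cc3)c3sccc3n2)cc(OC)c1OC`, differs from compound 3 by trifluoromethyl in place of isopropyl on an aromatic carbon. Among the measured compounds shown here, none of the measured steps touches this group; the two readable steps exchange the whole substituent on the nitrogen and both end at compound 3. No measured step therefore bears directly on the change, and nothing shown argues for a move beyond the scatter in either direction in this assay. The expected value for compound 4 is 400000 nM, with a range from 120000 nM to 1000000 nM. The step this estimate means, a 1.1-fold higher number from compound 3 to compound 4 (0.03 log units; within the scatter), is expected to lie within the scatter. A result that again returns only a limit remains possible for compound 4.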

Compound 4, half-maximal inhibitory concentration: 436000 nM
For compound 4 the middle estimate is 1.1-fold (0.04 log units) below the measured one; measured number inside the range.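

In this assay, among the compounds shown here, trifluoromethyl in place of isopropyl on an aromatic carbon para to a large group gives a 1.2-fold higher number from compound 3 to compound 4 (0.07 log units; within the scatter), the first reading at this position, and the two groups cannot be told apart here. A readable number no longer rests on compound 3 alone, since the second substituted phenylamino compound also separates from the cyclopropylamino and dimethylamino compounds, with an at least 2.2-fold lower number from compound 2 to compound 4 (0.36 log units; beyond the scatter) and with an at least 2.2-fold lower number from compound 1 to compound 4 (0.36 log units; beyond the scatter). These two steps are bounds and not full sizes, because one end of each rests on a limit and not on a number: the limit of > 1000000 nM in this assay, at which 2 of the 4 values shown sit.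

As far as these compounds go, what a hydroxyl, an amine or a carboxylic acid on this same aromatic carbon would give in this assay stays open, since isopropyl and trifluoromethyl span only a narrow part of the possible groups. Open too, from the compounds shown here alone, is how a plain phenyl on the nitrogen would compare with compound 3 and compound 4, which would show whether a group at this place is needed for a readable number at all.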